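The compounds below may be only part of what the source reports. "The series", "measured", "known", "first", "only" and "open" are said of these compounds alone.

Working notes on the series. In a functional assay on MKN-28 cells (Homo sapiens) for cytotoxicity, read by MTT assay (on this read-out lower numbers stand for stronger inhibition and higher numbers for weaker inhibition), compound 2 `C=C1C(=O)[C@]23C[C@@]1(OCC)CC[C@H]2[C@@]12C=CC(=O)[C@](C)(C(=O)O1)[C@H]2[C@@H]3C(=O)OC` reads 82700 nM as the higher of the two numbers, and compound 1 `C=C1C(=O)[C@]23C[C@@]1(O)CC[C@H]2[C@@]12C=CC(=O)[C@](C)(C(=O)O1)[C@H]2[C@@H]3C(=O)OCc1ccccc1` reads 2500 nM as the lower, a gap beyond the scatter. These two compounds differ in more than one place, so that gap isolates no single change. Compound 3 `C=C1C(=O)[C@]23C[C@@]1(OCC)CC[C@H]2[C@@]12C=CC(=O)[C@](C)(C(=O)O1)[C@H]2[C@@H]3C(=O)OCc1ccccc1` departs from compound 2 by phenyl in place of hydrogen on a saturated chain carbon bound to an oxygen next to a carbonyl group on a saturated chain carbon bound to an oxygen next to a carbonyl group, which reads as methoxycarbonyl to benzyloxycarbonyl. For the measured compounds named here, no measured step covers this change. Going by the values given here, the only guide is that compound 1 also carries benzyloxycarbonyl and reads 2500 nM in this assay as the lower number. A lower number beyond the scatter is therefore expected, and the estimated 6.9-fold lower number from compound 2 to compound 3 (0.84 log units; beyond the scatter) stays short of the full gap. The estimate for compound 3 is 12000 nM with an expected range from 3000 nM to 45000 nM.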

Compound 3, half-maximal inhibitory concentration: 16500 nM
Estimate against measurement, compound 3: 1.4-fold (0.14 log units) below; the measured number falls inside the stated range.
By their numbers in this assay, from the lowest: compound 1; then compound 3; then compound 2.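

With ethyl on the oxygen held constant in this assay, methoxycarbonyl to benzyloxycarbonyl gives a 5.0-fold lower number from compound 2 to compound 3 (0.70 log units; beyond the scatter) as a reading of that change alone. With benzyloxycarbonyl held constant, ethyl in place of hydrogen on an oxygen on a saturated carbon gives a 6.6-fold higher number from compound 1 to compound 3 (0.82 log units; beyond the scatter) and so also has a reading of its own. Each of the two changes therefore moves the number beyond the scatter, in opposite directions, but nothing at hand accounts for either step.

From the compounds shown here alone, only hydrogen and phenyl have been compared on the saturated chain carbon bound to an oxygen next to a carbonyl group, so it remains open how ethoxycarbonyl or a carboxylic acid would read in place of benzyloxycarbonyl. On the other oxygen, only hydrogen and ethyl are compared, which leaves a longer chain or an acetyl group unresolved.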